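The source may report more compounds than this note shows. Statements on the series, on what has been measured and on what is new or still open speak of the compounds shown alone.

In a functional assay on CCRF-CEM cells (Homo sapiens) for cytotoxicity, read by cell counting, with a stated time of 72 h (on this read-out lower numbers stand for stronger inhibition and higher numbers for weaker inhibition), compound 1 `Nc1nc(Cl)nc2ccsc12` gives > 250000 nM, which is a limit of the assay and not a number. Compound 2 `Clc1nc(-n2cncn2)c2sccc2n1` gives > 250000 nM, which is also a limit. For the measured compounds named here, compound 3 `Nc1nc(Cl)nc2c(Br)csc12`, at 109000 nM, therefore holds the only actual number so far. Compound 4 `Clc1nc(-n2cncn2)c2scc(Br)c2n1` differs from compound 3 in one place: 1H-1,2,4-triazol-1-yl in place of amino on an aromatic carbon. The same swap, made without the bromo, gave a step that the two limits leave unreadable from compound 1 to compound 2, so it offers no size to carry over. Bromo in place of hydrogen gave an at least 2.2-fold lower number from compound 1 to compound 3 (0.36 log units; beyond the scatter), and that bromo stays in place here. With no direction readable, no change beyond the scatter is expected. The estimated step is a 1.1-fold lower number from compound 3 to compound 4 (0.04 log units; within the scatter). Compound 4 is expected at 100000 nM, with an estimated range from 20000 nM to 250000 nM.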

Compound 4, half-maximal inhibitory concentration: 84000 nM
Compound 4: middle estimate off by 1.2-fold (0.08 log units), on the high side, within the range that was stated.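

With the bromo in place, 1H-1,2,4-triazol-1-yl in place of amino next to the ring nitrogen can now be sized, and it gives a 1.3-fold lower number from compound 3 to compound 4 (0.11 log units; within the scatter), so at this position the swap moves the number no further than repeated measurements would. Bromo in place of hydrogen now also appears on a second core, with an at least 2.9-fold lower number from compound 2 to compound 4 (0.47 log units; beyond the scatter). Its size on the two cores cannot be compared: the same change on two cores in this assay, an at least 2.2-fold lower number (0.36 log units; beyond the scatter) from compound 1 to compound 3 and an at least 2.9-fold lower number (0.47 log units; beyond the scatter) from compound 2 to compound 4; the limit leaves it open whether they differ

Going by these compounds, without the bromo, the same swap at this position stays unreadable: the limit of > 250000 nM in this assay, at which 2 of the 4 values shown sit. Whether a methoxy group, a carboxylic acid or an amine with a longer chain at this position would move the number beyond the scatter remains open.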